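Exchanging Methoxy for Fluoro: What to Expect for Compound 3

The source may report more compounds than this note shows. Statements on the series, on what has been measured and on what is new or still open speak of the compounds shown alone.

Compound 2 `COc1ccccc1/C=C/C(=O)/C=C/C1=C(C)CCCC1(C)C` was examined in a functional assay on MCF7 cells (Homo sapiens) for cytotoxicity, read by sulforhodamine B assay, with a stated time of 48 h (a lower number here means a stronger inhibitor, a higher number a weaker inhibitor), where compound 2 gives 13400 nM. Compound 1 `CC1=C(/C=C/C(=O)/C=C/c2ccc(C)cc2)C(C)(C)CCC1`, in this assay, gives 23800 nM. The two numbers lie within the usual scatter of each other, so neither compound can be set apart from the other on this evidence, and compound 2 simply has the lowest of the two numbers recorded so far.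

Compound 3 `CC1=C(/C=C/C(=O)/C=C/c2ccccc2F)C(C)(C)CCC1` has not yet been measured. It differs from compound 2 by fluoro in place of methoxy on an aromatic carbon. Going by the values given here, no pair of measured compounds isolates this particular change, so the direction of any effect cannot be read from the data at hand. The expectation for compound 3 in this assay is therefore a value close to that of compound 2, and the estimate is 15000 nM, with a range from 6000 nM to 40000 nM. The step that this estimate implies, a 1.1-fold higher number from compound 2 to compound 3 (0.05 log units; within the scatter), is expected to stay within the scatter rather than beyond it.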

Compound 3, half-maximal inhibitory concentration: 11000 nM
For compound 3 the middle estimate is 1.4-fold (0.13 log units) above the measured one; the measured number falls inside the stated range.
By their numbers in this assay, from the lowest: compounds 3, 2 and 1 (each within the scatter of the next, the first and the last beyond it).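

Taken as a direct pair in this assay, the exchange of methoxy for fluoro on an aromatic carbon ortho to a large group gives a 1.2-fold lower number from compound 2 to compound 3 (0.09 log units; within the scatter), so this position tolerates the change without a step that can be told from the scatter. The replacement of 4-methylphenyl by 2-fluorophenyl gives a 2.2-fold lower number from compound 1 to compound 3 (0.34 log units; beyond the scatter), a modest step and the only one shown that lies beyond the scatter, though it changes both the group and its place on the ring, and the two cannot be separated here. No measured property bears on either step.

Going by these compounds, it remains open what an amine, a carboxylic acid or chloro would give at this same place. On these data alone, it is also open whether fluoro elsewhere on the ring would match 2-fluorophenyl.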